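The compounds below may be only part of what the source reports. "The series", "measured", "known", "first", "only" and "open" are said of these compounds alone.

Compound 3, `CNC(=O)N1CCCc2ccc(NC(=O)c3ccc(-c4cnn(C(C)=O)c4)cc3)cc21`, is one of three related compounds built on a shared core and tested in a functional assay on MV4-11 cells (Homo sapiens) for antiproliferative activity, with a stated time of 6 days, tested at 1.56 uM; on this read-out higher numbers stand for a stronger effect at the one concentration tested and lower numbers for a weaker effect. Compound 3 gives 23.9%, which places it second highest of the three numbers. Compound 1, `CNC(=O)N1CCCc2ccc(NC(=O)c3ccc(-c4ccn(C)n4)cc3)cc21`, gives 72.2%, the highest of the three, while compound 2, `CNC(=O)N1CCCc2ccc(NC(=O)c3cccc(-c4cnn(S(C)(=O)=O)c4)c3)cc21`, gives 1.6%, the lowest.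

Compound 4, `CNC(=O)N1CCCc2ccc(NC(=O)c3ccc(-c4ccn(S(C)(=O)=O)n4)cc3)cc21`, is not yet measured. It differs from compound 3 in one place: 1-(methylsulfonyl)-1H-pyrazol-3-yl in place of 1-acetyl-1H-pyrazol-4-yl on an aromatic carbon. The new group is attached on an aromatic carbon of a six-membered aromatic ring of carbon only, para to a large group.

Going by the values given here, only one measured step bears on this change. Going from a 1-methyl-1H-pyrazol-3-yl to a 1-acetyl-1H-pyrazol-4-yl gave a number 48.3 percentage points lower from compound 1 to compound 3 (beyond the scatter), so the change at this position has moved the read-out strongly before. Compound 4 returns to the pyrazol-3-yl attachment seen in compound 1, but carries a methylsulfonyl group, as compound 2 does on a different attachment; compound 2 and compound 3 together show that the two ring variants with such groups both read low. Among the compounds with values here, no step that isolates the methylsulfonyl-for-acetyl exchange is available.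

The step expected from compound 3 to compound 4 is therefore a number 4.1 percentage points higher from compound 3 to compound 4 (within the scatter), within the scatter and in no clear direction. Compound 4 is estimated at 28%, with a range from 5% to 60%.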

Compound 4, a percentage reported as inhibition, at one concentration (the size of the read-out at that concentration, not a potency): 8.81%
Beside the measured number, compound 4's estimate is 19.2 percentage points above it; the range from low to high includes it.
By their numbers in this assay, from the lowest: compounds 2 and 4 (each within the scatter of the next); then compound 3; then compound 1.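

Keeping the 1H-pyrazol-3-yl attachment and putting methylsulfonyl in place of methyl on the aromatic nitrogen gives a number 63.4 percentage points lower from compound 1 to compound 4 (beyond the scatter) in this assay, so the group on that nitrogen can by itself remove most of the read-out, which no earlier pair could show. The step of a number 15.1 percentage points lower from compound 3 to compound 4 (beyond the scatter) adds that a return to the attachment of compound 1 does not restore the read-out when methylsulfonyl is the group on the nitrogen, although this step changes the attachment and the nitrogen group together and cannot assign the drop to either one. No measurement at hand explains why the read-out falls with these changes.

Still open, as far as these compounds go, is how much of the gap between compound 3 and compound 4 belongs to the attachment and how much to the group on the nitrogen, a question that a single exchange of acetyl and methylsulfonyl on one attachment would separate. Also open, from the compounds shown here alone, is how the read-out responds on that nitrogen to an ethyl group, a longer chain or a chain ending in an amine, and whether any of these comes close to methyl.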